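The source may report more compounds than this note shows. Statements on the series, on what has been measured and on what is new or still open speak of the compounds shown alone.

Working notes on the series

Compound 1 `O=C1/C(=C/c2ccccc2)CCC/C1=C\c1ccccc1[N+](=O)[O-]` and compound 3 `O=C1/C(=C/c2ccccc2)CCC/C1=C\c1ccc([N+](=O)[O-])cc1` share the same atoms joined differently; the difference between the two cores is not broken down here. In a physicochemical assay for lipophilicity (on this read-out higher numbers stand for higher lipophilicity and lower numbers for lower lipophilicity), compound 1 gives 4.7, and in this assay compound 3 gives 4.93. The two numbers lie within the usual scatter of each other, so nothing is read from their gap.

Compound 2 `O=C1/C(=C/c2ccc(F)cc2)CCC/C1=C\c1ccccc1[N+](=O)[O-]` is obtained from compound 1 by the change (fluoro in place of hydrogen on an aromatic carbon). In this assay compound 2 gives 4.86. The step is a number 0.16 log units higher from compound 1 to compound 2 (within the scatter), a move too small to stand out from repeated measurements.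

Compound 4 `O=C1/C(=C/c2ccc(F)cc2)CCC/C1=C\c1ccc([N+](=O)[O-])cc1` stands to compound 3 as compound 2 stands to compound 1: the change is fluoro in place of hydrogen on an aromatic carbon, the same change at a place described in the same words, made on the core of compound 3 instead of the core of compound 1. Among the compounds shown this change occurs twice in all.

For compound 4 in this assay the expected step is a number 0.16 log units higher from compound 3 to compound 4 (within the scatter), set beside the earlier step because the measured pair gave a number 0.16 log units higher from compound 1 to compound 2 (within the scatter) and the place of the change is the same in words. The expectation rests on one measured pair only, so the range is kept wide. Compound 4 is estimated at 5.09, with a likely span from 4.8 to 5.4.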

Compound 4, partition coefficient: 5.09
Beside the measured number, compound 4's estimate shows no gap at the digits printed; the range from low to high includes it.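

In this assay the new step reads a number 0.16 log units higher from compound 3 to compound 4 (within the scatter), and it sits at the same printed size as the earlier step, a number 0.16 log units higher from compound 1 to compound 2 (within the scatter), so fluoro in place of hydrogen on an aromatic carbon gives matching numbers on the core of compound 1 and the core of compound 3 in this pair of cases. Among the compounds shown here, this does not establish that the change has a real effect on either core, since neither step stands out from repeated measurements, and agreement between two small steps from only two pairs is weak support for carrying the change to any further core. No measurement among the data bears on why the two steps match, and the result is recorded here without an explanation.

The compounds shown leave open whether a step beyond the scatter appears when the hydrogen gives way to a group other than fluoro, such as an amine, a carboxylic acid or a longer chain, on either core. For the compounds shown here, they also leave open whether any such replacement would give steps of matching size on the two cores, as phenyl to 4-fluorophenyl does here, since only that one change occurs on both cores.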